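The source may hold more compounds than are shown below. What is called first, only, known or untested is meant among the compounds shown, and "the series" means these compounds.

Measured compounds:
compound 1 `CCOC(=O)C1=C(C)NC(COC(=O)c2ccccc2)=C(C(=O)OCC)C1c1cccc([N+](=O)[O-])c1` gives 210 nM in a functional assay on HEK293 cells for antagonist activity at Voltage-dependent L-type calcium channel subunit alpha-1C (Oryctolagus cuniculus), read by FLIPR; on this read-out higher numbers stand for weaker inhibition and lower numbers for stronger inhibition
compound 2 `CCOC(=O)C1=C(C)NC(C)=C(C(=O)OCCOC)C1c1cccc([N+](=O)[O-])c1` gives 16 nM in this assay
compound 3 `COC(=O)C1=C(C)NC(C)=C(C(=O)OCCCl)C1c1cccc([N+](=O)[O-])c1` gives 26 nM in this assay

On these three numbers compound 3 holds the second highest place. Its value lies close to that of compound 2, and the gap between them is within the scatter, so the two cannot be told apart. Compound 1 stands furthest away, with a clearly higher number, and that gap lies beyond the scatter.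

Compound 4 `COC(=O)C1=C(C)NC(C)=C(C(=O)OCc2ccc(OC)c(OC)c2)C1c1cccc([N+](=O)[O-])c1` has not yet been measured in this assay. It differs from compound 3 in one place: 3,4-dimethoxyphenyl in place of chloromethyl on a saturated chain carbon bound to an oxygen next to a carbonyl group. The shared core and the nitro-substituted aryl group are kept, and the change sits on the ester chain of one side of the core.

For the measured compounds named here, no pair of measured compounds that differ in only one place is available here, so the effect of such an ester change cannot be read off directly. Compound 1, which also carries a large ester-bearing group, gives 210 nM, while the smaller esters of compound 2 and compound 3 give lower numbers. On this ground the step of a 1.7-fold higher number from compound 3 to compound 4 (0.24 log units; within the scatter) is expected to be modest and toward a somewhat higher number, though possibly no larger than the scatter. Compound 4 is estimated to give about 45 nM in this assay, within a range from 12 nM to 170 nM.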

Compound 4, half-maximal inhibitory concentration: 112 nM
The estimate for compound 4 lay 2.5-fold (0.40 log units) below the measured number; the measured number falls inside the stated range.
By their numbers in this assay, from the lowest: compounds 2 and 3 (each within the scatter of the next); then compounds 4 and 1 (each within the scatter of the next).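

In this assay the ester chain now gives a step that can be read directly, and it is a 4.3-fold higher number from compound 3 to compound 4 (0.63 log units; beyond the scatter) when 2-chloroethyl gives way to 3,4-dimethoxybenzyl. Because this step lies beyond the scatter, the place on a saturated chain carbon bound to an oxygen next to a carbonyl group is shown to respond to what it carries, with inhibition weakened but still measured after a group of 2 heavy atoms and no ring is replaced by one of 10 heavy atoms with a six-membered aromatic ring and 2 hydrogen-bond acceptors. Nothing given here accounts for the weakening, so no cause can be assigned to it.

The compounds shown leave open whether the shift follows the aromatic ring itself or its two methoxy groups, as an unsubstituted benzyl or a 4-methoxybenzyl ester would separate the two. Also open, on these data alone, is how a longer chain, or an amine or a carboxylic acid at the end of this ester chain, would read in this assay at this same place.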